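Three Measured Compounds and a Fourth Awaiting Its Number

The source may report more compounds than this note shows. Statements on the series, on what has been measured and on what is new or still open speak of the compounds shown alone.

Measured so far in an assay on HeLa cells for displacement of a labelled ligand from adenosine receptor A3 (Homo sapiens), with a stated time of 180 min, tested at 10 uM; a lower number here means less inhibition, a higher number more inhibition at the concentration tested (going by the name of the read-out):
compound 1, `CC(=O)C1=C(C)NC(=O)NC1c1ccco1`, gives 14%
compound 2, `CC1=C(C(=O)OC(C)(C)C)C(c2ccco2)NC(=O)N1`, gives 7%
compound 3, `CCOC(=O)C1=C(C(F)(F)F)NC(=O)NC1c1ccco1`, gives 2%

Compound 3 holds the lowest of the three numbers in this assay. Its nearest neighbour is compound 2, whose value sits within the scatter of it, while compound 1 lies furthest away, beyond the scatter. For the measured compounds named here, the only step between compounds differing in one place is a number 7 percentage points lower from compound 1 to compound 2 (within the scatter), which concerns a tert-butoxy in place of methyl on a carbonyl carbon and says nothing about the ring carbon that is changed next.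

Compound 4, `CCOC(=O)C1=C(c2ccccc2)NC(=O)NC1c1ccco1`, differs from compound 3 as follows: phenyl in place of trifluoromethyl on a double-bonded ring carbon. Going by the values given here, no measured pair tests this exchange, so the account can only note that every number so far is small and that the one one-place step stayed within the scatter. Compound 4 is therefore expected to stay in the same low region, with an estimated step of a number 6 percentage points higher from compound 3 to compound 4 (within the scatter), not clearly beyond the scatter in either direction. Compound 4 is expected to give about 8%, within a range of 0% to 25%.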

Compound 4, a percentage reported as inhibition, at one concentration (the size of the read-out at that concentration, not a potency): 2%
The estimate for compound 4 lay 6 percentage points above the measured number; measured number inside the range.
By their numbers in this assay, from the lowest: compounds 3, 4, 2 and 1 (each within the scatter of the next, the first and the last beyond it).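

In this assay, placing phenyl where trifluoromethyl stood on the double-bonded ring carbon gives no change at the digits printed from compound 3 to compound 4 (within the scatter), the first one-place test of this position, next to the ring nitrogen and next to the ring atom that bears an ethoxycarbonyl group. The entering group has 6 heavy atoms and one six-membered aromatic ring of carbon only, whereas the leaving group has 4 heavy atoms and no ring, yet with the ethoxycarbonyl and furan-2-yl groups held fixed, this exchange leaves the read-out where it was. Nothing at hand accounts for this result.

Both groups exchanged here have 0 hydrogen-bond donors, 0 hydrogen-bond acceptors and no net charge, so the compounds shown leave open whether an amine or a carboxylic acid on this ring carbon would move the number beyond the scatter. They also leave open whether a longer chain or a methoxyphenyl group there would give a number like those of the trifluoromethyl and phenyl compounds, and whether the same exchange would read alike with an acetyl or tert-butoxycarbonyl group in place of the ethoxycarbonyl group.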